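The source may report more compounds than this note shows. Statements on the series, on what has been measured and on what is new or still open speak of the compounds shown alone.

Compound 3 `O=C(NC[C@@H]1C[C@@H]2C=C[C@@H]1C2)NS(=O)(=O)N1CCC(CCNC(=O)c2cc(Cl)ccn2)CC1` gives, in a functional assay on the whole organism (blood) with Rattus norvegicus as the target, with stated times of 24 h and 1 h, at a dose of 5 mg/kg by the intraperitoneal route (a lower number here means a weaker effect, a higher number a stronger effect of the compound at the dose given), a value of 32%. Two compounds share its core and differ only in the group on the carbonyl carbon: compound 1 `COc1ccc(Cl)cc1C(=O)NCCC1CCN(S(=O)(=O)NC(=O)NC[C@@H]2C[C@@H]3C=C[C@@H]2C3)CC1`, which gives 37%, and compound 2 `O=C(NC[C@@H]1C[C@@H]2C=C[C@@H]1C2)NS(=O)(=O)N1CCC(CCNC(=O)C(F)(F)F)CC1`, which gives 22%. For the measured compounds named here, the gap a number 5 percentage points lower from compound 1 to compound 3 (within the scatter) and the gap a number 10 percentage points higher from compound 2 to compound 3 (within the scatter) are both within the scatter, so compound 3 cannot be told apart from either neighbour with confidence; only the step of a number 15 percentage points lower from compound 1 to compound 2 (beyond the scatter) is beyond it.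

Compound 4 `O=C(NC[C@@H]1C[C@@H]2C=C[C@@H]1C2)NS(=O)(=O)N1CCC(CCNC(=O)c2ccc3ccccc3n2)CC1` is the next member of the series, with the change (quinolin-2-yl in place of 4-chloropyridin-2-yl on a carbonyl carbon). The three steps above all swap the group on this same carbonyl carbon, and two of them stayed within the scatter, with one modest drop. An aromatic group is kept here, so for compound 4 a step of about no change at the digits printed from compound 3 to compound 4 (within the scatter) is expected, which is none beyond the scatter. The estimate for compound 4 is therefore 32%, within a range from 15% to 50%.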

Compound 4, a percentage reported as activity, at one dose (the size of the read-out at that dose, not a potency): 21%
Compound 4: the middle estimate sits 11 percentage points above what was measured; the range from low to high includes it.
By their numbers in this assay, from the lowest: compounds 4, 2, 3 and 1 (each within the scatter of the next, the first and the last beyond it).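

Keeping an aromatic group on this carbonyl carbon does not by itself preserve the read-out in this assay: quinolin-2-yl in place of 4-chloropyridin-2-yl gives a number 11 percentage points lower from compound 3 to compound 4 (beyond the scatter), and quinolin-2-yl in place of 5-chloro-2-methoxyphenyl gives a number 16 percentage points lower from compound 1 to compound 4 (beyond the scatter). The position therefore separates one aromatic group from another, a difference the earlier compounds had not shown. Trifluoromethyl, which has no ring, gives a result that cannot be told apart from that of quinolin-2-yl, with a number 1 percentage points lower from compound 2 to compound 4 (within the scatter), so having an aromatic ring here does not set these two compounds apart.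

No measurement shown explains why quinolin-2-yl behaves differently from the other two aromatic groups. On these data alone, it also remains open how a longer alkyl chain or a carboxylic acid on this carbonyl carbon would compare.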